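Aryl variation on the piperazine nitrogen: towards compound 3

The source may hold more compounds than are shown below. What is called first, only, known or untested is meant among the compounds shown, and "the series" means these compounds.

Measured so far:
compound 1 `COc1ccccc1N1CCN(CCCN2C(=O)C3CCCCN3C2=O)CC1` — in an assay on isolated protein for binding affinity to Adrenergic receptor alpha-1 (Rattus norvegicus), read by radioligand binding (on this read-out lower numbers stand for stronger inhibition and higher numbers for weaker inhibition), compound 1 gives 9.9 nM
compound 2 `O=C1C2CCCCN2C(=O)N1CCCN1CCN(c2cccc(Cl)c2)CC1` — in this assay compound 2 gives 17.9 nM

Within the data shown here, compound 2 stands at the higher of the two numbers in this assay; its only neighbour is compound 1, and the step of a 1.8-fold higher number from compound 1 to compound 2 (0.26 log units; within the scatter) lies within the scatter, so the two values cannot be ordered.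

Compound 3 `O=C1C2CCCCN2C(=O)N1CCCN1CCN(c2ccc([N+](=O)[O-])cc2)CC1` has not yet been measured. It differs from compound 2 in one place: 4-nitrophenyl in place of 3-chlorophenyl on an amine nitrogen in a ring. Among the measured compounds shown here, the one measured step that bears on this is the earlier exchange of the aryl group on the same ring nitrogen, a 1.8-fold higher number from compound 1 to compound 2 (0.26 log units; within the scatter), which did not move the number beyond the scatter. A second exchange of the aryl group at that position is therefore expected to give a step of modest size in this assay; with two compounds the direction cannot be read from the data, and a slight drift to a higher number is assumed.

For compound 3 the expected step is a 2.2-fold higher number from compound 2 to compound 3 (0.35 log units; beyond the scatter). Compound 3 is estimated to give about 40 nM in this assay, between 10 nM and 160 nM.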

Compound 3, inhibition constant: > 1000 nM
Compound 3: a limit, no number; the forecaster's own chance of this, stated with the estimate: 5%; at least 25-fold (1.39 log units) between middle value and limit.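

In this assay compound 3 reads > 1000 nM, a limit and not a number: the limit of > 1000 nM in this assay, at which 1 of the 3 values shown sits.

The exchange of the aryl group on this ring nitrogen stayed within the scatter in a 1.8-fold higher number from compound 1 to compound 2 (0.26 log units; within the scatter), but that pair gave no sign of how far the number could move at this position. With 4-nitrophenyl the picture changes, giving an at least 55-fold higher number from compound 2 to compound 3 (1.74 log units; beyond the scatter) and an at least 100-fold higher number from compound 1 to compound 3 (2.00 log units; beyond the scatter), both large and beyond the scatter. The position on the piperazine side of the shared core is therefore not indifferent to the aryl group: 2-methoxyphenyl and 3-chlorophenyl give values that cannot be ordered, while 4-nitrophenyl falls far from both.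

Compound 3 differs from compound 1 and compound 2 both in the group carried by the aryl ring and in where that group stands, so the compounds shown cannot separate the nitro group from its place on the ring. On these data alone, whether a plain phenyl, or an amine or a nitrile in place of the nitro group, would return to the range of compound 1 and compound 2 remains open.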